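A few compounds are considered here, and "the series" means these few. Any claim that something is new, unique, unknown or untested is made for them only; others in the source may bear on it.

Compound 2 `COc1cc(OC)c2sc(-c3ccc(N/C=C\C(=O)c4cc(OC)c(OC)c(OC)c4)cc3)nc2c1` carries the shared core with two methoxy groups and a 3,4,5-trimethoxyphenyl on the carbonyl carbon. In a functional assay on HeLa cells (Homo sapiens) for antiproliferative activity, read by sulforhodamine B assay, with a stated time of 48 h (a lower number here means a stronger inhibitor, a higher number a weaker inhibitor), compound 2 gives 17800 nM, the highest of the three numbers measured. Compound 3 `COc1cc(OC)c2sc(-c3ccc(N/C=C\C(=O)c4ccc(OC)c(F)c4)cc3)nc2c1` is its closest neighbour; in this assay compound 3 gives 7300 nM, and the change from compound 2 to compound 3 is a 2.4-fold lower number from compound 2 to compound 3 (0.39 log units; beyond the scatter). Compound 1 `COc1cc(C(=O)/C=C\Nc2ccc(-c3nc4cc(OC)c(OC)c(OC)c4s3)cc2)c(Br)c(OC)c1OC` differs from compound 2 in two places. In this assay compound 1 gives 6600 nM.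

Compound 4 `COc1cc(OC)c2sc(-c3ccc(N/C=C\C(=O)c4cc(OC)c(OC)c(OC)c4Br)cc3)nc2c1` differs from compound 2 by bromo in place of hydrogen on an aromatic carbon. Within the data shown here, no measured step isolates this change. Among the measured compounds shown here, the only measured step, from compound 2 to compound 3, concerns a different aryl group on the carbonyl carbon and does not bear on a bromo substituent. Compound 1 bears a bromo on the same ring, ortho to the carbonyl-bearing carbon, and its number is lower than that of compound 2, but compound 1 also carries a third methoxy on the core, so the two values together only hint that a bromo there is compatible with a lower number.

Compound 4 is therefore expected to show a 2.1-fold lower number from compound 2 to compound 4 (0.32 log units; beyond the scatter), a modest shift. The estimate for compound 4 in this assay is 8500 nM, with an expected range from 3000 nM to 25000 nM.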

Compound 4, half-maximal inhibitory concentration: 10300 nM
Compound 4: middle estimate off by 1.2-fold (0.08 log units), on the low side; the measured number falls inside the stated range.
By their numbers in this assay, from the lowest: compounds 1, 3, 4 and 2 (each within the scatter of the next, the first and the last beyond it).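

In this assay, the step of a 1.7-fold lower number from compound 2 to compound 4 (0.24 log units; within the scatter) isolates bromo in place of hydrogen on an aromatic carbon, ortho to a large group, and shows that this single change stays within what repeated measurements would give. The step of a 1.6-fold higher number from compound 1 to compound 4 (0.19 log units; within the scatter) adds what the earlier pair could not show, since compound 1 and compound 2 differ in two places: with the bromo present on both sides, hydrogen in place of methoxy on an aromatic carbon also stays within the scatter, so neither change taken alone moves the number beyond it. Nothing at hand accounts for either of these results.

Going by these compounds, whether a chloro, an amine or a carboxylic acid on that same aromatic carbon would give a step beyond the scatter remains open. On these data alone, it is also open whether a bromo would give a similar step on the 3-fluoro-4-methoxyphenyl of compound 3, where the ring on the carbonyl carbon differs from that of compound 2.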